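This account rests on a few compounds, and the source may have more. Where it says the series, first, only, none or still open, it means among the compounds named here.

Measured so far in a functional assay for inhibition of transient receptor potential cation channel subfamily V member 1 (Homo sapiens), read by fluorescence and calcium flux; a higher number here means a weaker inhibitor, a lower number a stronger inhibitor:
compound 1 `COc1cc(-c2cc3c(O)nc(C)nc3cc2C(C)C)ccc1Cl`: 14 nM
compound 2 `CCc1nc(O)c2cc(-c3ccc(Cl)cc3)c(C(C)C)cc2n1`: > 1000 nM
compound 3 `CC(C)c1cc2nc(N)nc(O)c2cc1-c1ccc(Cl)cc1`: 133 nM

Compound 1 gives the lowest of the two numbers in this assay; the nearest is compound 3, whose number is higher, and that gap is beyond the scatter. For compound 2 the value is a limit of the assay and not a number (the limit of > 1000 nM in this assay, at which 1 of the 3 values shown sits). Among the compounds with values here, the only measured step, an at least 7.5-fold lower number from compound 2 to compound 3 (0.87 log units; beyond the scatter), concerns a substituent on the shared core and carries no information about the chain on the aromatic oxygen.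

Compound 4 `CCCCOc1cc(-c2cc3c(O)nc(C)nc3cc2C(C)C)ccc1Cl` differs from compound 1 by propyl in place of hydrogen on a saturated chain carbon bound to an oxygen on an aromatic ring. Within the data shown here, no measured step touches this place, so the expectation rests on compound 1 alone: a step of no more than modest size in either direction is expected, quite possibly one within the scatter. The estimate for compound 4 in this assay is 20 nM, with a range of 7 nM to 60 nM. This corresponds to an expected step of a 1.4-fold higher number from compound 1 to compound 4 (0.15 log units; within the scatter).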

Compound 4, half-maximal inhibitory concentration: 82 nM
Compound 4: the middle estimate sits 4.1-fold (0.61 log units) below what was measured; the measured number lies above the stated range.
By their numbers in this assay, from the lowest: compound 1; then compounds 4 and 3 (each within the scatter of the next). At a limit, above all of these: compound 2.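

In this assay, the substituent on the aromatic oxygen proves to be a place that responds to change: going from methoxy to butoxy gives a 5.9-fold higher number from compound 1 to compound 4 (0.77 log units; beyond the scatter). The step is modest and beyond the scatter, so this position accepts a longer chain at a measurable cost, with compound 4 still giving a measured 82 nM and not a limit of the assay. Nothing at hand bears on the cause of this step.

As far as these compounds go, with only methoxy and butoxy at this position, the shape of the trend stays open: an ethoxy or propoxy chain would show whether the number rises gradually with length or changes abruptly. Also open, from the compounds shown here alone, is how a branched chain, or a chain ending in an amine or a carboxylic acid, would read at this oxygen.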